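The compounds below may be only part of what the source reports. "The series", "measured", "known", "first", "only" and "open" are said of these compounds alone.

Compound 1 `COc1cc(OC)c(OC)cc1/C=C/COC(=O)/C=C/c1cc(OC)c(OC)c(OC)c1OC`: > 421 umol/kg
Compound 2 `COc1cc(OC)c(OC)cc1/C=C/COC(=O)/C=C/c1ccc(Br)cc1`: > 692 umol/kg
Compound 3 `COc1cc(OC)c(OC)cc1/C=C/COC(=O)/C=C/c1ccc(OC)c(OC)c1OC`: > 674 umol/kg

All three entries are limits of the assay and not numbers. In a functional assay on the whole organism (strain Kunming) with Mus musculus as the target, with a stated time of 0.5 h (a lower number here means that less compound is needed, a higher number that more compound is needed for the effect), compound 2 gives > 692 umol/kg, which is a limit. Its place among the three compounds therefore cannot be read. Compound 4 `COc1cc(OC)c(OC)cc1/C=C/COC(=O)/C=C/c1ccc(Cl)cc1` differs from compound 2 in one place: chloro in place of bromo on an aromatic carbon. Among the measured compounds shown here, the only measured step, a step that the two limits leave unreadable from compound 1 to compound 3, is a different change and gives no size to carry over. No step beyond the usual scatter is therefore expected in this assay. The estimated change is a step that the limit leaves unreadable from compound 2 to compound 4. For compound 4, the expected value is 770 umol/kg, with an estimated range of 400 umol/kg to 1500 umol/kg. A report of only a limit is also expected to be likely.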

Compound 4, dose for half-maximal effect: > 514 umol/kg
Compound 4 was reported as a limit; the forecaster's own chance of this, stated with the estimate: 85%; the middle value lies beyond the limit too.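

Compound 2 and compound 4 are both reported only as limits in this assay, and the step between them, chloro in place of bromo, cannot be read. The compounds shown leave open what dose of any of them gives the half-maximal effect.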